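The source may hold more compounds than are shown below. What is called first, only, known or untested is meant among the compounds shown, and "the series" means these compounds.

Compound 1 `CC1CCCC(C(=O)N2CC(c3nc(-c4cccc(Cl)c4)no3)C2)C1` — in an assay on HEK293 cells for negative allosteric modulation of metabotropic glutamate receptor 5 (Homo sapiens), read by FLIPR (on this read-out lower numbers stand for stronger inhibition and higher numbers for weaker inhibition), compound 1 gives > 10000 nM, a limit of the assay and not a number.
Compound 2 `Cc1ccc(C(=O)N2CC(c3nc(-c4cccc(F)c4)no3)C2)cc1` — in this assay compound 2 gives > 10000 nM, likewise a limit.

Compound 1 sits at the limit of > 10000 nM in this assay, at which 2 of the 2 values shown sit, so no number is known for it. Compound 3 `O=C(C1CCC(F)(F)CC1)N1CC(c2nc(-c3cccc(Cl)c3)no2)C1` is not yet measured in this assay. The change is 4,4-difluorocyclohexyl in place of 3-methylcyclohexyl on a carbonyl carbon. Going by the values given here, no measured pair fixes the size of such a step, so the expected step of a number no higher from compound 1 to compound 3 (the limit leaves the size open) is none beyond the scatter. Compound 3 is expected at 10000 nM, with a range from 2000 nM to 30000 nM, most probably again only a limit.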

Compound 3, half-maximal inhibitory concentration: > 10000 nM
Compound 3 was reported as a limit; the forecaster's own chance of this, stated with the estimate: 70%; the middle value lies on the limit itself.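

Compound 3 gives > 10000 nM, a limit of the assay and not a number. Compound 1 also stands at a limit, so no step from compound 1 to compound 3 can be read: the limit of > 10000 nM in this assay, at which 3 of the 3 values shown sit.

The compounds shown leave open which change on the shared core, if any, would give a measurable value.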